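Nucleoside analogues against the equilibrative transporter: a substitution series

The compounds below may be only part of what the source reports. "The series", "measured", "known", "first", "only" and "open" are said of these compounds alone.

Compound 1 `CCCCCNc1ncnc2c1ncn2[C@@H]1O[C@H](CO)[C@@H](O)[C@H]1O`: 13500 nM
Compound 2 `Cc1cccc(CSc2ncnc3c2ncn3[C@@H]2O[C@H](CO)[C@@H](O)[C@H]2O)c1`: 12000 nM
Compound 3 `OC[C@H]1O[C@@H](n2cnc3c(CSc4ccc(F)cc4)ncnc32)[C@H](O)[C@@H]1O`: 158 nM

In an assay on isolated protein for binding affinity to Equilibrative nucleoside transporter 1 (Homo sapiens) (a lower number here means a stronger inhibitor, a higher number a weaker inhibitor), compound 1 gives 13500 nM, the highest of the three numbers. Compound 2 sits nearest, with a 1.1-fold lower number from compound 1 to compound 2 (0.05 log units; within the scatter), while compound 3 is furthest, with an 85-fold lower number from compound 1 to compound 3 (1.93 log units; beyond the scatter). The step of a 76-fold lower number from compound 2 to compound 3 (1.88 log units; beyond the scatter) shows the same gap from the other side.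

Compound 4 `Cc1ccc([N+](=O)[O-])c(CNc2ncnc3c2ncn3[C@@H]2O[C@H](CO)[C@@H](O)[C@H]2O)c1` has not yet been measured in this assay. It differs from compound 1 by 5-methyl-2-nitrophenyl in place of butyl on a saturated chain carbon bound to a nitrogen on an aromatic ring. Among the measured compounds shown here, the step that bears most directly on this change is the one from compound 1 to compound 2, in which an aromatic ring likewise entered the side group and the number hardly moved. The large steps to compound 3 concern a different way of attaching the side group to the shared core and therefore give less guidance here.

On that basis, compound 4 is expected to show a 1.9-fold lower number from compound 1 to compound 4 (0.29 log units; within the scatter) in this assay, a step that may well stay within the scatter. The estimate for compound 4 is 7000 nM, with a range from 1500 nM to 30000 nM.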

Compound 4, half-maximal inhibitory concentration: 1290 nM
Compound 4: the middle estimate sits 5.4-fold (0.73 log units) above what was measured; the measured number lies below the stated range.
By their numbers in this assay, from the lowest: compound 3; then compound 4; then compounds 2 and 1 (each within the scatter of the next).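

In this assay, the change from butyl to 5-methyl-2-nitrophenyl on a saturated chain carbon bound to a nitrogen on an aromatic ring is a large one (a 10-fold lower number from compound 1 to compound 4 (1.02 log units; beyond the scatter)), so the number at this position does respond to what the side group carries. The earlier step from pentylamino to (3-methylbenzyl)sulfanyl (a 1.1-fold lower number from compound 1 to compound 2 (0.05 log units; within the scatter)) replaced the whole side group, including the atom attached to the shared core, and so could not show this; its result does not carry over to a change that keeps the nitrogen in place, and a ring entering the side group need not leave the number unmoved. Nothing available here accounts for the gain seen with compound 4.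

The entering group brings in a ring, a methyl and a nitro group at once, and the compounds shown do not separate them; a plain phenyl, or a 5-methyl-2-aminophenyl group, on the same carbon would begin to do so. As far as these compounds go, it also remains open whether a carboxylic acid or a methoxy group in place of the nitro group would give a similar number.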